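The compounds below may be only part of what the source reports. "The series", "measured", "known", "first", "only" and "open" are said of these compounds alone.

Compound 1 `COc1cc(/C=C/C(=O)Nc2ccccc2)ccc1OCCCN1CCCC1` belongs to a small set of three amides sharing one core and differing only in the amine-bearing side chain. In a physicochemical assay for lipophilicity, using the shake flask method, measured as octanol-water partition, at pH 7.4 (on this read-out higher numbers stand for higher lipophilicity and lower numbers for lower lipophilicity), compound 1 gives 1.57. Compound 2 `CCN(CC)CCCCOc1ccc(/C=C/C(=O)Nc2ccccc2)cc1OC` gives 1.59, and compound 3 `COc1cc(/C=C/C(=O)Nc2ccccc2)ccc1OCCCCCN1CCCCC1` gives 1.65; the steps of a number 0.02 log units higher from compound 1 to compound 2 (within the scatter), a number 0.08 log units higher from compound 1 to compound 3 (within the scatter) and a number 0.06 log units higher from compound 2 to compound 3 (within the scatter) all stay within the scatter, so the three stand together. Compound 4 `COc1cc(/C=C/C(=O)Nc2ccccc2)ccc1OCCCCCCCCN(C)C` differs from compound 1 by 5-(dimethylamino)pentyl in place of pyrrolidin-1-yl on a saturated chain carbon, three bonds along the chain from an oxygen on an aromatic ring. The steps from compound 1 to compounds 2 and 3 are the relevant ones, as they too reshape that side chain. Because a number 0.08 log units higher from compound 1 to compound 3 (within the scatter) came with added heavy atoms yet stayed within the scatter, only a small rise at most is expected, a number 0.28 log units higher from compound 1 to compound 4 (within the scatter). Compound 4 is therefore estimated at 1.85, between 1.4 and 2.4.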

Compound 4, partition coefficient: 1.74
Estimate against measurement, compound 4: 0.11 log units above; low and high end bracket the measured number.
By their numbers in this assay, from the lowest: compounds 1, 2, 3 and 4 (each within the scatter of the next).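

In this assay, putting 5-(dimethylamino)pentyl in place of pyrrolidin-1-yl gives a number 0.17 log units higher from compound 1 to compound 4 (within the scatter), so losing the ring and adding heavy atoms at this chain position leaves the read-out within the scatter. The steps of a number 0.09 log units higher from compound 3 to compound 4 (within the scatter) and a number 0.15 log units higher from compound 2 to compound 4 (within the scatter) are also within the scatter, so all four compounds stand together, even with a dimethylamino end on this chain. No measurement here explains why these numbers stay so close. As far as these compounds go, it remains open whether a side chain ending in a carboxylic acid, or a plain alkyl chain with no amine, would stay with them.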